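The source may report more compounds than this note shows. Statements on the series, on what has been measured and on what is new or still open speak of the compounds shown alone.

Of the compounds shown here, two built on the same core have been tested so far. In a functional assay on LNCaP cells (Homo sapiens) for cytotoxicity, read by MTT assay (on this read-out lower numbers stand for stronger inhibition and higher numbers for weaker inhibition), compound 1 (`COc1cccc(CSc2nnc([C@@H](C)c3ccc4cc(OC)ccc4c3)n2-c2ccc(Cl)cc2)c1`) gives 162000 nM, while compound 2 (`COc1ccc(CSc2nnc([C@@H](C)c3ccc4cc(OC)ccc4c3)n2-c2ccc(F)cc2)cc1`) gives 22800 nM. Compound 2 therefore has the lower of the two numbers, and the gap between them lies beyond the usual scatter of repeated measurements.

Compound 3 (`COc1cccc(CSc2nnc([C@@H](C)c3ccc4cc(OC)ccc4c3)n2-c2ccc(F)cc2)c1`) has the same atoms as compound 2, joined differently: 3-methoxyphenyl in place of 4-methoxyphenyl on a saturated chain carbon bound to a sulfur. In words, a 3-methoxyphenyl stands in place of a 4-methoxyphenyl on a saturated chain carbon bound to a sulfur. For the measured compounds named here, no measured pair isolates this change, so any forecast is uncertain. The closest clue is compound 1, which also carries the 3-methoxyphenyl group and gives 162000 nM, although it differs from compound 3 elsewhere too.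

A moderate move towards a higher number, meaning weaker inhibition, is therefore expected, and the estimated step is a 2.4-fold higher number from compound 2 to compound 3 (0.38 log units; beyond the scatter). In this assay, the estimated value for compound 3 is 55000 nM, with an expected range from 17000 nM to 170000 nM.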

Compound 3, half-maximal inhibitory concentration: 14500 nM
Beside the measured number, compound 3's estimate is 3.8-fold (0.58 log units) above it, outside the stated range (below it).
By their numbers in this assay, from the lowest: compounds 3 and 2 (each within the scatter of the next); then compound 1.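

In this assay, 3-methoxyphenyl in place of 4-methoxyphenyl on a saturated chain carbon bound to a sulfur gives a 1.6-fold lower number from compound 2 to compound 3 (0.20 log units; within the scatter), so this swap of two groups with the same atoms changes the read-out no more than repeated measurements of one compound might. Compound 3 also provides the one-place comparison that the first two compounds lacked: with the 3-methoxyphenyl group held constant, fluoro in place of chloro on an aromatic carbon gives an 11-fold lower number from compound 1 to compound 3 (1.05 log units; beyond the scatter), a large step that shows this aromatic substituent has much more influence here than the methoxyphenyl swap. No measurement shown here explains either result.

Going by these compounds, the fluoro and chloro comparison rests on this single pair, so it remains open whether the same swap would have a similar effect alongside the 4-methoxyphenyl group. The compounds shown also leave open how a bromo group or a plain hydrogen would behave in place of the fluoro group, and what an amine or a carboxylic acid would do in place of the methoxy group.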